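Swapping chloro for bromo on a phenolic chalcone

The source may report more compounds than this note shows. Statements on the series, on what has been measured and on what is new or still open speak of the compounds shown alone.

Measured compounds:
- Compound 1, `COc1cc(Br)cc(/C=C/C(=O)c2ccc(Cl)cc2)c1O`: 5330 nM
- Compound 2, `COc1cccc(C(=O)/C=C/c2cc(Br)ccc2O)c1`: 7270 nM
- Compound 3, `Cc1ccc(C(=O)/C=C/c2cc(Cl)ccc2O)cc1`: 4800 nM

Of the compounds shown here, three have been tested in a functional assay on Hs-578T cells (Homo sapiens) for antiproliferative activity, read by sulforhodamine B assay, with a stated time of 72 h (on this read-out lower numbers stand for stronger inhibition and higher numbers for weaker inhibition), all of them giving concentrations in the low micromolar region. In this assay compound 3 gives 4800 nM, the lowest of the three numbers, but its gap to compound 1 and to compound 2 both lie within the usual scatter, so the three cannot be ranked against one another.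

Compound 4, `Cc1ccc(C(=O)/C=C/c2cc(Br)ccc2O)cc1`, has not yet been measured. It differs from compound 3 by a single change: bromo in place of chloro on an aromatic carbon. Compound 1 and compound 2 both carry bromo, but neither is a one-change partner of a chloro compound, so the step is not known from these data. Since a halogen is exchanged for a closely related halogen, no step beyond the scatter is expected. Compound 4 is therefore estimated at 4500 nM, with a likely range from 2000 nM to 10000 nM, which corresponds to an expected step of a 1.1-fold lower number from compound 3 to compound 4 (0.03 log units; within the scatter).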

Compound 4, half-maximal inhibitory concentration: 1600 nM
Compound 4: the middle estimate sits 2.8-fold (0.45 log units) above what was measured, outside the stated range (below it).
By their numbers in this assay, from the lowest: compound 4; then compounds 3, 1 and 2 (each within the scatter of the next).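

For the compounds shown here, this pair is the first in the set to differ in one place. In this assay, bromo in place of chloro, on an aromatic carbon para to a hydroxy group, gives a 3.0-fold lower number from compound 3 to compound 4 (0.48 log units; beyond the scatter), so the choice of halogen at this position matters, even though no ring, hydrogen-bond donor, acceptor or net charge changes. Compounds 1 and 2 also carry bromo, but neither has a chloro partner differing in one place, and the step holds only for the core shared by compound 3 and compound 4; nothing available here explains the difference.

Open, from the compounds shown here alone, is whether the trend continues with iodo at this position, or what fluoro, methyl or an amine would do there. Also open, going by these compounds, is whether the same exchange would give a similar step on the core of compound 1 or compound 2.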